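Swapping an aryl for a thienyl in two enone series

The source may report more compounds than this note shows. Statements on the series, on what has been measured and on what is new or still open speak of the compounds shown alone.

Compound 1 `Cc1ccsc1/C=C(/SCc1ccc(Cl)cc1)C(=O)c1ccc(Cl)cc1` in a functional assay on DU-145 cells (Homo sapiens) for inhibition, read by trypan blue exclusion, with a stated time of 96 h (a higher number here means a weaker inhibitor of growth, a lower number a stronger inhibitor of growth), gives 50000 nM. Compound 2 `COc1ccccc1/C=C(\C(=O)c1ccc(Br)cc1)S(=O)(=O)c1ccc(C)cc1` gives 1000 nM. Compound 3 `COc1ccccc1/C=C(/SCc1ccc(Cl)cc1)C(=O)c1ccc(Cl)cc1` gives 1000 nM.

The values of compound 2 and compound 3 are level at the digits given, and the difference between their two cores is not broken down here. From compound 3 to compound 1 the change is 3-methylthiophen-2-yl in place of 2-methoxyphenyl on a double-bonded chain carbon bound to a double-bonded chain carbon, and it made a large step, a 50-fold higher number from compound 3 to compound 1 (1.70 log units; beyond the scatter).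

Compound 4 `Cc1ccc(S(=O)(=O)/C(=C/c2sccc2C)C(=O)c2ccc(Br)cc2)cc1` is not yet measured. It differs from compound 2 by the same change, (3-methylthiophen-2-yl in place of 2-methoxyphenyl on a double-bonded chain carbon bound to a double-bonded chain carbon), at the same place. Because the step of a 50-fold higher number from compound 3 to compound 1 (1.70 log units; beyond the scatter) was large, a step of similar size is expected here, a 30-fold higher number from compound 2 to compound 4 (1.48 log units; beyond the scatter). Compound 4 is therefore estimated at 30000 nM, expected to fall between 5000 nM and 100000 nM, though this rests on a single earlier instance of the change.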

Compound 4, concentration for 50% growth inhibition: 25000 nM
The estimate for compound 4 lay 1.2-fold (0.08 log units) above the measured number; the range from low to high includes it.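

In this assay, 3-methylthiophen-2-yl in place of 2-methoxyphenyl again gave a large move towards weaker growth inhibition on the second core, with a 25-fold higher number from compound 2 to compound 4 (1.40 log units; beyond the scatter). The change therefore carried from one core to the other with its size preserved within the scatter: the same change on two cores in this assay, a 50-fold higher number (1.70 log units; beyond the scatter) from compound 3 to compound 1 and a 25-fold higher number (1.40 log units; beyond the scatter) from compound 2 to compound 4, 2.0-fold (0.30 log units) apart, within the scatter of two such steps. This agreement rests on two cores only, so it does not show that the change would behave alike on any other core, and it does not show which part of the 3-methylthiophen-2-yl group accounts for the step.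

The compounds shown leave open what a plain thiophen-2-yl group, without the methyl, would give at this place. They also leave open how a phenyl ring bearing an amine or a carboxylic acid would compare there.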